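Methyl in place of hydrogen on an indole-type core

The source may hold more compounds than are shown below. What is called first, only, known or untested is meant among the compounds shown, and "the series" means these compounds.

Measured so far:
compound 1, `COc1ccc(/C(Cl)=C/C=C(\C#N)C(=O)c2c(C)[nH]c3ccccc23)cc1`: 74%
compound 2, `COc1ccc(/C(Cl)=C/C=C(\C#N)C(=O)c2c[nH]c3ccccc23)cc1OC`: 75%

Both compounds share the chloro-styryl nitrile ketone chain and differ in the aromatic ends. In a functional assay for inhibition, read by Griess assay, with a stated time of 150 min, tested at 1 mM (on this read-out higher numbers stand for more inhibition at the one concentration tested (going by the name of the read-out) and lower numbers for less inhibition), compound 1 gives 74% and compound 2 gives 75%. Compound 2 carries the higher of the two numbers, but its nearest neighbour, compound 1, lies within the scatter of it, so the two cannot be told apart on these data. For the measured compounds named here, no pair differing in a single place has been measured, so no size of step is known.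

Compound 3, `COc1ccc(/C(Cl)=C/C=C(\C#N)C(=O)c2c(C)[nH]c3ccccc23)cc1OC`, is not yet measured. It differs from compound 2 by methyl in place of hydrogen on an aromatic carbon. The same methyl is present in compound 1, which with one methoxy less gives a value indistinguishable from that of compound 2. On that basis the expected no change at the digits printed from compound 2 to compound 3 (within the scatter) is none beyond the scatter, in either direction. Compound 3 is therefore estimated to give 75% in this assay, with a range from 62% to 86%.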

Compound 3, a percentage reported as inhibition, at one concentration (the size of the read-out at that concentration, not a potency): 75.8%
Compound 3: middle estimate off by 0.8 percentage points, on the low side, within the range that was stated.
By their numbers in this assay, from the lowest: compounds 1, 2 and 3 (each within the scatter of the next).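

In this assay, for the compounds shown here, methyl in place of hydrogen on the aromatic carbon next to the ring nitrogen gives the first single-place reading at this position: a number 0.8 percentage points higher from compound 2 to compound 3 (within the scatter). The methoxy change can now also be read on its own, as a number 1.8 percentage points higher from compound 1 to compound 3 (within the scatter). Neither step lies beyond the scatter, so at the one concentration tested the read-out does not distinguish methyl from hydrogen at this position, or methoxy from hydrogen at the other, and no evidence at hand bears on the reason for this result.

At this position the compounds shown hold only hydrogen and methyl, so it stays open whether an ethyl group, an amine or a carboxylic acid there would give a number outside the scatter. From the compounds shown here alone, it also stays open whether these compounds would still be indistinguishable at other concentrations, as a reading at one concentration is not a potency.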